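A methoxy for a fluoro on the aniline ring

A few compounds are considered here, and "the series" means these few. Any claim that something is new, unique, unknown or untested is made for them only; others in the source may bear on it.

Measured compounds:
compound 1, `Cc1cnc(Nc2ccc([N+](=O)[O-])cc2)nc1Nc1nc2ccccc2s1`: 34300 nM
compound 2, `Cc1cnc(Nc2ccc(F)cc2)nc1Nc1nc2ccccc2s1`: > 50000 nM

In a functional assay on HeLa cells (Homo sapiens) for antiproliferative activity, read by MTT assay, with a stated time of 48 h (on this read-out lower numbers stand for stronger inhibition and higher numbers for weaker inhibition), compound 1 gives 34300 nM. Compound 2 in this assay gives only a limit, > 50000 nM, and not a number. Compound 2 thus sits at the limit of > 50000 nM in this assay, at which 1 of the 2 values shown sits. For the measured compounds named here, the single measured step, an at least 1.4-fold higher number from compound 1 to compound 2 (0.16 log units; that floor lies within the scatter), has a floor that lies within the scatter, so it gives no clear direction. Compound 3, `COc1cccc(Nc2ncc(C)c(Nc3nc4ccccc4s3)n2)c1`, differs from compound 2 by 3-methoxyphenyl in place of 4-fluorophenyl on a nitrogen on an aromatic ring. Going by the values given here, the one known step concerns a change on the same ring and is not resolved beyond the scatter, so no step beyond the scatter in this assay is expected, and a limit again is quite possible. Compound 3 is expected near 45000 nM, with a range from 15000 nM to 150000 nM. The expected step is an at least 1.1-fold lower number from compound 2 to compound 3 (0.04 log units; that floor lies within the scatter).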

Compound 3, half-maximal inhibitory concentration: > 50000 nM
Compound 3: no number, only a limit; the forecaster's own chance of this, stated with the estimate: 55%; at least 1.1-fold (0.04 log units) between middle value and limit.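

Putting 3-methoxyphenyl in place of 4-fluorophenyl on the nitrogen leaves the read-out in this assay at the assay limit once more: the limit of > 50000 nM in this assay, at which 2 of the 3 values shown sit. The step between compound 2 and compound 3 cannot be read, as both ends are limits, so neither the change of group nor the change of ring position shows any effect that can be sized. Against the only value in the set that is a number, the replacement of 4-nitrophenyl by 3-methoxyphenyl gives an at least 1.4-fold higher number from compound 1 to compound 3 (0.16 log units; that floor lies within the scatter), so this comparison gives no clear direction either.

Going by these compounds, it remains open whether any group on this ring can bring the read-out clearly under the limit, and how far compound 2 and compound 3 lie past it. An amine or a carboxylic acid on this ring would be one test of that.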